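Changing the nitrogen substituent of a weak inhibitor

The source may hold more compounds than are shown below. What is called first, only, known or untested is meant among the compounds shown, and "the series" means these compounds.

Compound 1 `Cn1c(=O)c(S(=O)(=O)c2ccc(F)cc2F)cc2cnc(Nc3ccc4[nH]ncc4c3)nc21` gives 30000 nM
Compound 2 `Cn1c(=O)c(S(=O)(=O)c2ccc(F)cc2)cc2cnc(Nc3ccc4[nH]ncc4c3)nc21` gives 5000 nM
Compound 3 `Cn1c(=O)c(S(=O)(=O)c2ccc(O)cc2)cc2cnc(Nc3ccc4[nH]ccc4c3)nc21` gives 250 nM

In a functional assay on DU-145 cells (Homo sapiens) for inhibition, read by trypan blue exclusion, with a stated time of 72 h (a higher number here means a weaker inhibitor, a lower number a stronger inhibitor), compound 1 has the highest number of the three (30000 nM), which makes it the weakest inhibitor of the set. The next compound to be measured is compound 4 `Cn1c(=O)c(S(=O)(=O)c2ccc(F)cc2F)cc2cnc(NCc3ccc4[nH]ccc4c3)nc21`, which keeps the core of compound 1 but changes one group: (1H-indol-5-yl)methyl in place of 1H-indazol-5-yl on a nitrogen on an aromatic ring. Read one bond further out, ((1H-indol-5-yl)methyl)amino stands in place of (1H-indazol-5-yl)amino.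

Going by the values given here, the only measured step that changes a single place is a 6.0-fold lower number from compound 1 to compound 2 (0.78 log units; beyond the scatter) and it concerns a fluoro on an aromatic carbon, not the group on the nitrogen. It is a modest step, so it offers only a rough guide to size. Compound 3 (250 nM) shows that much lower numbers occur in this set, but it differs from compound 1 in more than one place. No measurement isolates the new group, so its direction is uncertain. Among the compounds with values here, the numbers so far leave more room downward than upward from compound 1. The step expected in this assay is a 3.0-fold lower number from compound 1 to compound 4 (0.48 log units; beyond the scatter) and it is a modest, uncertain one. For compound 4 the estimated value is 10000 nM with 1500 nM to 40000 nM as its expected range.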

Compound 4, half-maximal inhibitory concentration: 100000 nM
For compound 4 the middle estimate is 10-fold (1.00 log units) below the measured one; the measured number lies above the stated range.
By their numbers in this assay, from the lowest: compound 3; then compound 2; then compound 1; then compound 4.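

In this assay there is now a measured change at this nitrogen, and it goes upward, giving a weaker inhibitor: a 3.3-fold higher number from compound 1 to compound 4 (0.52 log units; beyond the scatter). Going by these compounds alone, the only earlier single-place step, a 6.0-fold lower number from compound 1 to compound 2 (0.78 log units; beyond the scatter), concerned a fluoro on an aromatic carbon, so it said nothing about this nitrogen, whereas the new step shows that the group carried here can shift the number beyond the usual scatter, even starting from a compound as weak as compound 1. This one step bundles two differences, a methyl link on the nitrogen and a five-membered ring with 1 hetero atom instead of 2, and no measurement available here explains the rise or divides it between them.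

The compounds shown leave open which of those two differences carries the step, and (1H-indazol-5-yl)methyl on the same nitrogen would be the group that separates them. They also leave open how a longer chain such as 2-(1H-indol-5-yl)ethyl, or a simple phenyl in place of the two-ring group, would read on the core of compound 1.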